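Bromo in Place of Fluoro: Compound 3 to Compound 4

A few compounds are considered here, and "the series" means these few. Any claim that something is new, unique, unknown or untested is made for them only; others in the source may bear on it.

In an ADME assay on HaCaT cells (Homo sapiens) for cytotoxicity, read by MTT assay, with a stated time of 48 h (on this read-out higher numbers stand for weaker inhibition and lower numbers for stronger inhibition), compound 3 (`COc1ccc(-c2nn(-c3ccccc3)cc2-c2nc3cc(F)ccc3[nH]2)cc1`) gives > 50000 nM, which is a limit of the assay and not a number. Compound 4 (`COc1ccc(-c2nn(-c3ccccc3)cc2-c2nc3cc(Br)ccc3[nH]2)cc1`) differs from it by bromo in place of fluoro on an aromatic carbon and is otherwise the same.

For the measured compounds named here, no measured step makes this exchange, so the evidence is indirect. Compound 1 (`Brc1ccc2[nH]c(-c3cn(-c4ccccc4)nc3-c3ccccc3)nc2c1`) gives > 50000 nM, also a limit of the assay. Compound 2 (`Fc1ccc(-c2nn(-c3ccccc3)cc2-c2nc3cc(Br)ccc3[nH]2)cc1`), which carries bromo as well, gives 21800 nM as a true number. Going by the values given here, the one measured step is an at least 2.2-fold lower number from compound 1 to compound 2 (0.36 log units; beyond the scatter), and it concerns fluoro in place of hydrogen, not the change at hand.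

Because of the limit of > 50000 nM in this assay, at which 2 of the 3 values shown sit, only a modest step towards lower numbers is expected, and compound 4 may well stay at the limit. In this assay compound 4 is estimated at 32000 nM (expected range 13000 nM to 70000 nM). This estimate means an at least 1.5-fold lower number from compound 3 to compound 4 (0.19 log units; that floor lies within the scatter) as the expected step.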

Compound 4, half-maximal inhibitory concentration: > 50000 nM
Compound 4 gave a limit, no number (the forecaster's own chance of this, stated with the estimate: 45%); at least 1.5-fold (0.19 log units) between middle value and limit.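

In this assay, bromo in place of fluoro on an aromatic carbon gives no readable change, and the steps from compound 3 and from compound 1 to compound 4 cannot be read, as each joins two limits. Compound 4 adds a comparison with compound 2 that holds bromo on the core: exchanging the fluoro group of that compound for a methoxy group gives an at least 2.2-fold higher number from compound 2 to compound 4 (0.36 log units; beyond the scatter). Compound 2 remains the only one of the four compounds with a true number, and the other three stand at a limit: the limit of > 50000 nM in this assay, at which 3 of the 4 values shown sit.

The compounds shown leave open whether bromo and fluoro differ at all in this assay on this methoxy-bearing compound. They also leave open whether a chloro group or an amine on the same aromatic carbon would give a true number.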